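Swapping the methoxy of compound 3 for methyl

The compounds below may be only part of what the source reports. "The series", "measured", "known", "first", "only" and "open" are said of these compounds alone.

Compound 1 `COc1ccc(C2=C(c3ccc(SC)cc3)CC3CCCN3C2=O)cc1O`: 6000 nM
Compound 2 `COc1ccc(C2=C(c3ccc(SC)cc3)CC3CCCN3C2=O)cc1OC(=O)CNC(=O)OC(C)(C)C`: 7000 nM
Compound 3 `COc1ccc(C2=C(c3ccc(SC)cc3)CC3CCCN3C2=O)cc1C`: 100 nM

In a functional assay on NCI-H520 cells (Homo sapiens) for cytotoxicity (on this read-out lower numbers stand for stronger inhibition of growth and higher numbers for weaker inhibition of growth), compound 3 holds the lowest of the three numbers, at 100 nM. Both of its gaps lie beyond the scatter: a 60-fold lower number from compound 1 to compound 3 (1.78 log units; beyond the scatter), and a 70-fold lower number from compound 2 to compound 3 (1.85 log units; beyond the scatter). The remaining step, a 1.2-fold higher number from compound 1 to compound 2 (0.07 log units; within the scatter), lies within the scatter.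

The next compound to be tested is compound 4 `CSc1ccc(C2=C(c3ccc(C)c(C)c3)C(=O)N3CCCC3C2)cc1`, which keeps the rest of compound 3 and changes one group: methyl in place of methoxy on an aromatic carbon. This is methyl in place of methoxy on an aromatic carbon, turning 4-methoxy-3-methylphenyl into 3,4-dimethylphenyl.

For the measured compounds named here, no measured step touches this methoxy, so the evidence is indirect. The closest is a 60-fold lower number from compound 1 to compound 3 (1.78 log units; beyond the scatter), where methyl also enters on an aromatic carbon, but at a different place. It shows that a small exchange on this ring can move the number widely, yet its direction need not carry over. Going by the values given here, a moderate rise seems likelier than a fall because compound 3 already gives 100 nM, the lowest number so far. The expected step is a 3.0-fold higher number from compound 3 to compound 4 (0.48 log units; beyond the scatter). Compound 4 is estimated at 300 nM, with an expected range of 80 nM to 1500 nM.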

Compound 4, concentration for 50% growth inhibition: 300 nM
Estimate against measurement, compound 4: no gap at the digits printed; the measured number falls inside the stated range.
By their numbers in this assay, from the lowest: compound 3; then compound 4; then compounds 1 and 2 (each within the scatter of the next).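

In this assay, for the compounds shown here, this is the first change to the methoxy itself, and replacing it with methyl gives a 3.0-fold higher number from compound 3 to compound 4 (0.48 log units; beyond the scatter). That modest step shows that the methoxy of compound 3 can be exchanged at a limited cost, a much smaller shift than the large steps seen when the neighbouring ring substituent changed among compounds 1, 2 and 3. Across the whole ring, the exchange of 3-hydroxy-4-methoxyphenyl for 3,4-dimethylphenyl gives a 20-fold lower number from compound 1 to compound 4 (1.30 log units; beyond the scatter), so compound 4 keeps most of the gain over compound 1, though compound 3 still has the lowest number; no supporting data are available to explain either step.

The compounds shown leave open how an ethoxy group, a longer alkoxy chain, a chlorine atom or an amine would read at this position, since only methoxy and methyl can be compared there. They also leave open whether the step from methoxy to methyl would hold with a hydroxy group or another substituent in place of the methyl group on the same ring.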